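Benzyl amide in place of propyl: an expected outcome

The source may hold more compounds than are shown below. What is called first, only, known or untested is meant among the compounds shown, and "the series" means these compounds.

Compound 1 `C=CC1=C(C(=O)NCCC)C(c2ccc(Cl)c(Cl)c2)OC1` was tested in a functional assay on SW480 cells (Homo sapiens) for cytotoxicity, read by MTT assay, with a stated time of 24 h; on this read-out higher numbers stand for weaker inhibition and lower numbers for stronger inhibition. In this assay compound 1 gives > 100000 nM, which is a limit of the assay and not a number. Compound 2 `C=CC1=C(C(=O)Nc2ccccc2)C(c2ccc(OC)cc2)OC1` in this assay gives > 100000 nM, likewise a limit. Compound 1 therefore stands at the limit of > 100000 nM in this assay, at which 2 of the 2 values shown sit. Compound 3 `C=CC1=C(C(=O)NCc2ccccc2)C(c2ccc(Cl)c(Cl)c2)OC1` carries phenyl in place of ethyl on a saturated chain carbon bound to an amide-type nitrogen. Going by the values given here, no measured pair of compounds shows what such a change does here, so nothing beyond the scatter can be read from the data. The step from a number no higher from compound 1 to compound 3 (the limit leaves the size open) is expected to stay within the scatter, with no gain beyond it. Compound 3 is thus estimated at 100000 nM, expected to fall between 30000 nM and 300000 nM.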

Compound 3, half-maximal inhibitory concentration: > 100000 nM
Compound 3 gave a limit, no number; the forecaster's own chance of this, stated with the estimate: 70%; the middle value lies on the limit itself.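

Going by these compounds alone, compound 3, like compound 1, gives only a limit and not a number, so no step between the two can be read: the limit of > 100000 nM in this assay, at which 3 of the 3 values shown sit. The compounds shown leave open whether phenyl in place of ethyl changes cytotoxicity at all.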